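A few compounds are considered here, and "the series" means these few. Any claim that something is new, unique, unknown or untested is made for them only; others in the source may bear on it.

Measured so far:
compound 1, `CNc1nc(Cl)nc2c1ncn2[C@@H]1O[C@H](C(=O)NC2CC2)[C@@H](O)[C@H]1O` — in an assay on CHO cells for displacement of a labelled ligand from adenosine receptor A3 (Homo sapiens) (a higher number here means a weaker inhibitor, a lower number a stronger inhibitor), compound 1 gives 2.82 nM.
compound 2, `CNc1nc(Cl)nc2c1ncn2[C@@H]1O[C@H](C(=O)NCCC(C)C)[C@@H](O)[C@H]1O` — in this assay compound 2 gives 1.62 nM.

Compound 2 has the lower of the two numbers, but the step of a 1.7-fold lower number from compound 1 to compound 2 (0.24 log units; within the scatter) lies within the scatter, so the two compounds cannot be told apart. Compound 3, `CNc1nc(Cl)nc2c1ncn2[C@@H]1O[C@H](C(=O)N2CCOCC2)[C@@H](O)[C@H]1O`, differs from compound 2 by morpholin-4-yl in place of isopentylamino on a carbonyl carbon. Among the measured compounds shown here, the only measured step exchanges one chain for another on an amide-type nitrogen and keeps the amide hydrogen; no measured step removes it, so that step bears only loosely on the change here. A step toward a higher number is nevertheless expected, a 93-fold higher number from compound 2 to compound 3 (1.97 log units; beyond the scatter), and compound 3 is estimated at 150 nM, with a range of 20 nM to 1500 nM.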

Compound 3, inhibition constant: 3890 nM
Estimate against measurement, compound 3: 26-fold (1.41 log units) below; measured number above the stated range.
By their numbers in this assay, from the lowest: compounds 2 and 1 (each within the scatter of the next); then compound 3.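

In this assay this position on the carbonyl carbon turns out to be highly sensitive: morpholin-4-yl brings a 2400-fold higher number from compound 2 to compound 3 (3.38 log units; beyond the scatter) and a 1400-fold higher number from compound 1 to compound 3 (3.14 log units; beyond the scatter) as large steps, although cyclopropylamino and isopentylamino could not be told apart. Among the compounds shown here, compound 3 is the only compound here without the amide hydrogen, and it also brings in a ring oxygen, so two things change at once. Nothing available explains the loss.

Going by these compounds, whether the lost amide hydrogen or the ring oxygen matters more remains open. Dimethylamino or piperidin-1-yl on the same carbonyl carbon would help separate the two.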